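Methoxy in place of hydrogen, compound 1 to compound 3

The source may hold more compounds than are shown below. What is called first, only, known or untested is meant among the compounds shown, and "the series" means these compounds.

Compound 1 `O=C(Nc1nccn2cc(-c3ccccc3)nc12)c1ccccc1` gives 52 nM in an assay on cells for displacement of a labelled ligand from transmembrane domain-containing protein TMIGD3 (Homo sapiens), read by scintillation counting, with a stated time of 120 min (a higher number here means a weaker inhibitor, a lower number a stronger inhibitor), and stands alongside compound 2 `O=C(c1ccccc1)N(C(=O)c1ccccc1)c1nccn2cc(-c3ccccc3)nc12`, which gives 64 nM in this assay; the step of a 1.2-fold higher number from compound 1 to compound 2 (0.09 log units; within the scatter) lies within the scatter. Compound 3 `COc1ccc(C(=O)Nc2nccn3cc(-c4ccccc4)nc23)cc1` carries the change (methoxy in place of hydrogen on an aromatic carbon), methoxy in place of hydrogen on an aromatic carbon, para to a large group. Among the compounds with values here, no measured step touches this ring; the only step, a 1.2-fold higher number from compound 1 to compound 2 (0.09 log units; within the scatter), concerns the amide nitrogen and was flat. For compound 3 the expected step is a 1.0-fold lower number from compound 1 to compound 3 (0.02 log units; within the scatter) in this assay, none beyond the scatter. Compound 3 is estimated at 50 nM, between 20 nM and 150 nM.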

Compound 3, inhibition constant: 162 nM
The estimate for compound 3 lay 3.2-fold (0.51 log units) below the measured number; measured number above the stated range.
By their numbers in this assay, from the lowest: compounds 1 and 2 (each within the scatter of the next); then compound 3.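

Phenyl to 4-methoxyphenyl gives the first step in the series beyond the scatter: a 3.1-fold higher number from compound 1 to compound 3 (0.49 log units; beyond the scatter) in this assay on this ring, para to a large group. Within the data shown here, the number therefore responds to a change at this place, whereas the only earlier step, a 1.2-fold higher number from compound 1 to compound 2 (0.09 log units; within the scatter) at the amide nitrogen, stayed within the scatter. No evidence on hand explains the rise.

Open is whether the step belongs to methoxy specifically: the compounds shown do not tell how fluoro, hydroxy or an amine at the same place would read.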